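The source may hold more compounds than are shown below. What is called first, only, known or untested is meant among the compounds shown, and "the series" means these compounds.

Working notes on the series. Compound 1 `CC(C)=CCOc1cc(Nc2nccs2)ccc1C(C)C` gives 31000 nM in a functional assay on MT2 cells (Homo sapiens) for cytotoxicity; a higher number here means that more compound is tolerated, a lower number that less compound is tolerated. Compound 2 `CC(C)=CCOc1cc(Nc2nccs2)ccc1C#N` gives 500 nM, after a 62-fold lower number from compound 1 to compound 2 (1.79 log units; beyond the scatter). Compound 3 `CC(C)=CCOc1cc(Nc2ccccn2)ccc1C#N` gives 290 nM, the lowest of the three numbers, though a 1.7-fold lower number from compound 2 to compound 3 (0.24 log units; within the scatter) leaves compound 2 and compound 3 indistinguishable. The next compound, compound 4 `CC(C)=CCOc1cc(Nc2ccccn2)ccc1C`, differs from compound 3 by methyl in place of cyano on an aromatic carbon. Going by the values given here, the only step that bears on this change is the one in which cyano entered, a 62-fold lower number from compound 1 to compound 2 (1.79 log units; beyond the scatter); here cyano leaves and an alkyl returns, so the reverse direction is expected, with a step of unknown size since methyl is not isopropyl. Compound 4 is therefore expected to give a higher number in this assay, roughly a 17-fold higher number from compound 3 to compound 4 (1.24 log units; beyond the scatter), estimated at 5000 nM within 1500 nM to 25000 nM.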

Compound 4, half-maximal cytotoxic concentration: 35000 nM
For compound 4 the middle estimate is 7.0-fold (0.85 log units) below the measured one; measured number above the stated range.
By their numbers in this assay, from the lowest: compounds 3 and 2 (each within the scatter of the next); then compounds 1 and 4 (each within the scatter of the next).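

Replacing cyano with methyl on this aromatic carbon, para to the (pyridin-2-yl)amino group, gives a 120-fold higher number from compound 3 to compound 4 (2.08 log units; beyond the scatter) in this assay. Read with a 62-fold lower number from compound 1 to compound 2 (1.79 log units; beyond the scatter), the nitrile-bearing compound has the lower number in both pairs, so the link no longer rests on the 1,3-thiazol-2-yl compounds alone, and neither pair goes against it. Nothing here gives a reason for this step. As far as these compounds go, whether a chlorine atom, a carboxylic acid or an amine at this carbon would track with the nitrile or with the alkyl groups stays open. Methyl on the 1,3-thiazol-2-yl amine also remains open.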